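A few compounds are considered here, and "the series" means these few. Any claim that something is new, unique, unknown or untested is made for them only; others in the source may bear on it.

Three acrylamides have been measured in an ADME assay for pharmacokinetics, read by LC-MS, in phosphate buffer, with a stated time of 120 min, at pH 7.4, tested at 1 uM, in the presence of a further agent that is not named here (on this read-out lower numbers stand for a shorter-lived compound and higher numbers for a longer-lived compound), and a fourth awaits measurement. Compound 1 `C=C(Cc1ccccc1)C(=O)Nc1ccccc1` reaches only the limit of the assay, > 8.53 h, and gives no number. Compound 2 `C=C(CO)C(=O)Nc1ccccc1` likewise stops at the limit, > 8.53 h. Compound 3 `C=C(Cl)C(=O)Nc1ccccc1` is the one compound with a number: in this assay compound 3 gives 0.05 h, the lowest figure shown. Going by the values given here, the move an at least 170-fold lower number from compound 2 to compound 3 (2.23 log units; beyond the scatter) is the only readable step, since the move a step that the two limits leave unreadable from compound 1 to compound 2 cannot be sized because both of its values sit at the limit of > 8.53 h in this assay, at which 2 of the 3 values shown sit. Compound 4 `C=C(CCO)C(=O)Nc1ccccc1` differs from compound 3 by 2-hydroxyethyl in place of chloro on a double-bonded chain carbon bound to a carbonyl carbon. The change places a 2-hydroxyethyl where compound 2 carries hydroxymethyl, on a double-bonded chain carbon bound to a carbonyl carbon, so the expected effect is a large rise running opposite to the large fall seen from hydroxymethyl to chloro. Compound 4 is therefore expected to give 8 h, within 1 h to 25 h. The expected step is a 160-fold higher number from compound 3 to compound 4 (2.20 log units; beyond the scatter), with a real chance that only the limit is reported.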

Compound 4, half-life: > 8.53 h
Compound 4 was reported as a limit; the forecaster's own chance of this, stated with the estimate: 60%; middle value at least 1.0-fold (0.02 log units) away from the limit.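

At the double-bonded chain carbon bound to a carbonyl carbon, 2-hydroxyethyl in place of chloro gives an at least 170-fold higher number from compound 3 to compound 4 (2.23 log units; beyond the scatter), so a second group with a hydroxy end now stands far from chloro, where before only hydroxymethyl did. In this assay, going by these compounds alone, compound 1, compound 2 and compound 4 all carry a carbon chain at this place and all give only a limit, while compound 3, with chloro, is the one compound with a number. Hydroxymethyl and 2-hydroxyethyl therefore cannot be told apart, and no step among these three compounds can be read: the limit of > 8.53 h in this assay, at which 3 of the 4 values shown sit.

The compounds shown leave open where the half-lives of compound 1, compound 2 and compound 4 really lie. They also leave open whether chloro stands alone at this place, or whether bromo, an amine or a carboxylic acid there would also give a low number.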